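Chain Lengthening in Two Linker Series of a Shared Core

This account rests on a few compounds, and the source may have more. Where it says the series, first, only, none or still open, it means among the compounds named here.

Compound 1, with the structure `CN(C)C(=O)c1cc2cnc(Nc3ccc(S(=O)(=O)NCCCN=C=S)cc3)nc2n1C1CCCC1`, gives 58.9% in a functional assay on A549 cells (Homo sapiens) for inhibition, read by CCK-8 assay, with a stated time of 72 h, tested at 1 uM; a higher number here means a stronger effect of the compound at the concentration tested, a lower number a weaker effect. Compound 2, `CN(C)C(=O)c1cc2cnc(Nc3ccc(S(=O)(=O)NCCCCN=C=S)cc3)nc2n1C1CCCC1`, differs from it by a group of 4 heavy atoms (2 carbon, 1 nitrogen, 1 sulfur; no ring) in place of a group of 3 heavy atoms (1 carbon, 1 nitrogen, 1 sulfur; no ring), on a saturated chain carbon, three bonds along the chain from a sulfonamide nitrogen, and this change made the step of a number 19.5 percentage points lower from compound 1 to compound 2 (beyond the scatter). In this assay compound 2 gives 39.4%. Compound 3, `CN(C)C(=O)c1cc2cnc(Nc3ccc(C(=O)NCCCCCCN=C=S)cc3)nc2n1C1CCCC1`, carries a different linker arm; its core differs from that of compound 1 by a group of 12 heavy atoms (8 carbon, 2 nitrogen, 1 oxygen, 1 sulfur; no ring) in place of a group of 10 heavy atoms (4 carbon, 2 nitrogen, 2 oxygen, 2 sulfur; no ring), on an aromatic carbon, and in this assay compound 3 gives 35.8%. The step of a number 23.1 percentage points lower from compound 1 to compound 3 (beyond the scatter) puts compound 3 well under compound 1, while the step of a number 3.6 percentage points lower from compound 2 to compound 3 (within the scatter) leaves compound 2 and compound 3 indistinguishable.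

Compound 4, `CN(C)C(=O)c1cc2cnc(Nc3ccc(C(=O)NCCCCCCCN=C=S)cc3)nc2n1C1CCCC1`, is not yet measured. It differs from compound 3 by a group of 4 heavy atoms (2 carbon, 1 nitrogen, 1 sulfur; no ring) in place of a group of 3 heavy atoms (1 carbon, 1 nitrogen, 1 sulfur; no ring), on a saturated chain carbon, six bonds along the chain from an amide-type nitrogen. This is the same kind of change as that from compound 1 to compound 2, but not the same change: there the site was three bonds along the chain from a sulfonamide nitrogen, here it is six bonds along the chain from an amide-type nitrogen. Going by the values given here, the single precedent, a number 19.5 percentage points lower from compound 1 to compound 2 (beyond the scatter), points downward, and compound 4 is expected to lose a little ground because compound 3 starts from 35.8%; the expected step is a number 7.8 percentage points lower from compound 3 to compound 4 (within the scatter). For compound 4 the estimated value in this assay is 28%, with a likely range from 14% to 42%.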

Compound 4, a percentage reported as inhibition, at one concentration (the size of the read-out at that concentration, not a potency): 73.7%
Beside the measured number, compound 4's estimate is 45.7 percentage points below it; measured number above the stated range.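

In this assay, the group of 4 heavy atoms in place of the group of 3 heavy atoms, on a saturated chain carbon, six bonds along the chain from an amide-type nitrogen, gave a step of a number 37.9 percentage points higher from compound 3 to compound 4 (beyond the scatter). The same kind of change therefore did not carry over from the sulfonamide arm to the amide-type arm, neither in direction nor in size: the same change on two cores in this assay, a number 19.5 percentage points lower (beyond the scatter) from compound 1 to compound 2 and a number 37.9 percentage points higher (beyond the scatter) from compound 3 to compound 4, 57.4 percentage points apart, beyond the scatter of two such steps This shows that the earlier step could not be transferred to the other linker arm, but it does not show which difference between the two cases matters, since the two sites differ both in the kind of nitrogen and in the distance along the chain, and each direction rests on a single pair.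

Left open is how a longer chain would read on either arm, and whether the two arms would give matching numbers at equal chain length. Also open, from the compounds shown here alone, is how an amine or a carboxylic acid would read in place of the group exchanged here.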